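The source may hold more compounds than are shown below. What is called first, only, known or untested is meant among the compounds shown, and "the series" means these compounds.

Measured compounds in the series:

- compound 1, `CC(C)Nc1sc(C(=O)c2ccc(C#N)cc2)c(N)c1C#N`: > 5000 nM
- compound 2, `CC(C)Nc1sc(C(=O)c2ccc(Cl)s2)c(N)c1C#N`: 192 nM
- compound 3, `CC(C)N(C)c1sc(C(=O)c2ccc(Cl)s2)c(N)c1C#N`: 1420 nM

In an assay for inhibition of Maternal embryonic leucine zipper kinase (Homo sapiens), read by ADP-Glo, with a stated time of 0.5 h (a higher number here means a weaker inhibitor, a lower number a stronger inhibitor), compound 1 gives only a limit, > 5000 nM, and no number. Of the two numbers shown, compound 3 stands highest; the step of a 7.4-fold higher number from compound 2 to compound 3 (0.87 log units; beyond the scatter) sets it apart from compound 2, and the limit of > 5000 nM in this assay, at which 1 of the 3 values shown sits, is the only other point of reference.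

Compound 4, `CCNc1sc(C(=O)c2ccc(Cl)s2)c(N)c1C#N`, has not yet been measured in this assay. It differs from compound 3 in one place: ethylamino in place of isopropyl(methyl)amino on an aromatic carbon. Two things change at once: the methyl on the nitrogen is removed, so that a hydrogen-bond donor returns, and an ethyl stands where the isopropyl stood.

Among the measured compounds shown here, only one measured step bears on this change. Putting a methyl on that nitrogen, a 7.4-fold higher number from compound 2 to compound 3 (0.87 log units; beyond the scatter), raised the number well beyond the scatter. Taking the methyl off again is expected to reverse most of that movement. For the change from isopropyl to ethyl no step is available among the compounds shown, so no extra allowance is made for it.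

Compound 4 is therefore expected to give about 250 nM in this assay, in a range of 100 nM to 700 nM, which corresponds to an expected step of a 5.7-fold lower number from compound 3 to compound 4 (0.75 log units; beyond the scatter).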

Compound 4, half-maximal inhibitory concentration: 222 nM
Beside the measured number, compound 4's estimate is 1.1-fold (0.05 log units) above it; measured number inside the range.
By their numbers in this assay, from the lowest: compounds 2 and 4 (each within the scatter of the next); then compound 3. At a limit, above all of these: compound 1.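

Read in this assay, the exchange of isopropyl(methyl)amino for ethylamino on this aromatic carbon (a 6.4-fold lower number from compound 3 to compound 4 (0.81 log units; beyond the scatter)) shows that the cost seen on adding the methyl to the nitrogen does not persist once that nitrogen again carries a hydrogen and a shorter chain stands on it. The comparison with the isopropylamino compound (a 1.2-fold higher number from compound 2 to compound 4 (0.06 log units; within the scatter)) lies within the scatter, so ethyl and isopropyl cannot be told apart on a nitrogen that keeps its hydrogen, and among compounds 2, 3 and 4 only compound 3, the one with a fully substituted nitrogen, stands apart. The measurements shown offer no cause for either the separation of compound 3 or the match between compound 2 and compound 4.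

Still open, from the compounds shown here alone, is how far the chain on this nitrogen can vary, from a plain amino group to a cyclopropyl group, a longer chain such as butyl, or a chain ending in a hydroxyl or an amine. Also open, going by these compounds, is whether a methyl on the nitrogen of the ethylamino group would give a step of the same size as the one seen with the isopropylamino group.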